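This account rests on a few compounds, and the source may have more. Where it says the series, first, only, none or still open, it means among the compounds named here.

Measured compounds:
compound 1 `COc1ccc(-c2cc(/C=C/C(=O)c3ccc(N)cc3)[nH]n2)cc1` — -78%
compound 2 `COc1cc(-c2cc(/C=C/C(=O)c3ccc(Cl)c(Cl)c3)[nH]n2)cc(OC)c1OC` — 11%
compound 3 `COc1ccc(C(=O)/C=C/c2cc(-c3cc(OC)c(OC)c(OC)c3)n[nH]2)cc1` — 7%

In a functional assay on SN12C cells (Homo sapiens) for cytotoxicity, read by sulforhodamine B assay, with a stated time of 48 h, tested at 100 uM (on this read-out higher numbers stand for a weaker effect at the one concentration tested and lower numbers for a stronger effect), compound 1 gives -78%, the lowest of the three numbers. Compound 3 gives 7% and compound 2 gives 11%; both of these numbers lie higher than that of compound 1 by gaps beyond the scatter, so compound 1 shows the strongest effect of the three at the one concentration tested. Within the data shown here, the only step between measured compounds that differ in one place is a number 4 percentage points lower from compound 2 to compound 3 (within the scatter), a swap on the carbonyl carbon that left the number essentially unchanged.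

Compound 4 `COc1ccc(-c2cc(/C=C/C(=O)c3ccc(N)cc3)[nH]n2)cc1OC` is not yet measured. It differs from compound 1 by methoxy in place of hydrogen on an aromatic carbon. Among the measured compounds shown here, no measured step touches this place: the one step known concerns the group on the carbonyl carbon, not the ring carrying the methoxy, so it does not bear on the change in hand. With nothing pointing either way, the working expectation is that compound 4 stays close to compound 1, with a step of a number 18 percentage points higher from compound 1 to compound 4 (beyond the scatter) that is not expected to go beyond the scatter. From the compounds shown here alone, compound 4 is therefore estimated at -60%, within a range of -95% to -5%, kept wide since a second methoxy on this ring is untested.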

Compound 4, a percentage reported as activity, at one concentration (the size of the read-out at that concentration, not a potency): -90%
For compound 4 the middle estimate is 30 percentage points above the measured one, within the range that was stated.
By their numbers in this assay, from the lowest: compound 4; then compound 1; then compounds 3 and 2 (each within the scatter of the next).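

In this assay, methoxy in place of hydrogen on an aromatic carbon, ortho to a methoxy group and meta to a large group, gives a number 12 percentage points lower from compound 1 to compound 4 (beyond the scatter) as a modest step towards a stronger effect at the one concentration tested. Among these compounds, this is the first reading at this place, and it shows that the added methoxy, with its 2 heavy atoms and 1 hydrogen-bond acceptor, does not cost the effect already seen with compound 1. Nothing measured here speaks to why the step occurs.

From the compounds shown here alone, it remains open whether this step is particular to methoxy or would also appear with another group at the same place, such as a hydroxyl, a fluorine or an ethoxy. Also open, going by these compounds, is whether the step carries over when the amine shared by compound 1 and compound 4 is replaced by another group on that ring, such as a dimethylamino group or an acetamide.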